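The compounds below may be only part of what the source reports. "The series", "measured", "known", "first", "only" and "open" are said of these compounds alone.

Measured compounds:
compound 1, `CS(=O)(=O)c1ccc(Nc2nccc(Nc3nc4ccc(F)cc4s3)n2)cc1`: 1940 nM
compound 2, `CS(=O)(=O)c1ccc(Nc2nccc(Nc3nc4ccccc4s3)n2)cc1`: 1710 nM
compound 3, `COc1ccc2nc(Nc3nc(Nc4ccc(S(N)(=O)=O)cc4)ncc3F)sc2c1`: > 50000 nM

Compounds 1 and 2 share a core and were tested in a functional assay on PC-3 cells (Homo sapiens) for antiproliferative activity, read by MTT assay, with a stated time of 48 h; on this read-out lower numbers stand for stronger inhibition and higher numbers for weaker inhibition. The change between them is hydrogen in place of fluoro on an aromatic carbon, and the step of a 1.1-fold lower number from compound 1 to compound 2 (0.05 log units; within the scatter) falls within the scatter. For compound 3 the read-out is a limit of the assay, not a number, and the value > 50000 nM sits at the limit of > 50000 nM in this assay, at which 1 of the 3 values shown sits. How the core of compound 3 differs from that of compound 1 is not broken down here.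

Compound 4, `COc1ccc2nc(Nc3ccnc(Nc4ccc(S(N)(=O)=O)cc4)n3)sc2c1`, has not yet been measured. It differs from compound 3 by hydrogen in place of fluoro on an aromatic carbon. This is the same kind of change as that from compound 1 to compound 2, but not the same: there the place was a six-membered aromatic ring of carbon only, part of a fused or bridged system of two rings, meta to a fused ring and para to a fused ring; here it is a six-membered aromatic ring with 2 nitrogen, ortho to a large group, two atoms from the ring nitrogen and para to a large group.

The step of an at least 1.6-fold lower number from compound 3 to compound 4 (0.22 log units; that floor lies within the scatter) is expected to be small, resting on compound 1 to compound 2 giving a 1.1-fold lower number from compound 1 to compound 2 (0.05 log units; within the scatter). Compound 4 is therefore estimated at 30000 nM, with a range from 8000 nM to 100000 nM, and a limit is again a real possibility.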

Compound 4, half-maximal inhibitory concentration: 3030 nM
Beside the measured number, compound 4's estimate is 9.9-fold (1.00 log units) above it, outside the stated range (below it).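

Hydrogen in place of fluoro does not carry over as one fixed step between the two cores in this assay: the same change on two cores in this assay, a 1.1-fold lower number (0.05 log units; within the scatter) from compound 1 to compound 2 and an at least 16-fold lower number (1.21 log units; beyond the scatter) from compound 3 to compound 4, at least 14-fold (1.16 log units) apart, beyond the scatter of two such steps

The change gives an at least 16-fold lower number from compound 3 to compound 4 (1.21 log units; beyond the scatter), but two pairs cannot settle whether the place of the change or the rest of the core sets this gap, and they say nothing about why the steps differ.

Compound 3 stands at > 50000 nM, a limit of the assay and not a number, so the step from it is a floor and its full size stays unknown: the limit of > 50000 nM in this assay, at which 1 of the 4 values shown sits.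

Open, on these data alone, is whether fluoro on the same carbon of the six-membered aromatic ring with 2 nitrogen in compound 2 would give a step of the kind seen with compound 4. Also open, as far as these compounds go, is how a chloro, a methyl or an amine at that place would read in this assay on either core.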